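This account rests on a few compounds, and the source may have more. Where it says the series, first, only, none or still open, it means among the compounds named here.

Series notes.
Compound 1 `Cc1ccnc(Nc2cc(N3CCC[C@@H](N)C3)nc3ccnn23)c1`; compound 2 `N[C@@H]1CCCN(c2cc(Nc3cc(Cl)ccn3)n3nccc3n2)C1`.

In an assay on isolated protein for inhibition of Dipeptidyl peptidase 9 (Homo sapiens) (a lower number here means a stronger inhibitor, a higher number a weaker inhibitor), compound 1 gives only a limit, > 100000 nM. In this assay compound 2 likewise gives only a limit, > 50000 nM. The step that the two limits leave unreadable from compound 1 to compound 2 is thus unreadable. Compound 1 sits at the limit of > 100000 nM in this assay, at which 1 of the 2 values shown sits. Compound 2 sits at the limit of > 50000 nM in this assay, at which 1 of the 2 values shown sits.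

Compound 3 `Cc1ccc(Nc2cc(N3CCC[C@@H](N)C3)nc3ccnn23)c(C)c1` differs from compound 2 by 2,4-dimethylphenyl in place of 4-chloropyridin-2-yl on a nitrogen on an aromatic ring. No measured step bears on this change, and the one shown step has no readable size, so no move beyond the scatter is expected in this assay; the estimated step that the limit leaves unreadable from compound 2 to compound 3 reflects that. Compound 3 is expected to give 80000 nM in this assay, between 20000 nM and 300000 nM.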

Compound 3, half-maximal inhibitory concentration: > 100000 nM
Compound 3: only a limit was reported; the forecaster's own chance of this, stated with the estimate: 80%; at least 1.2-fold (0.09 log units) between middle value and limit.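

In this assay compound 3 gives only a limit, > 100000 nM. Among the compounds shown here, no step among compound 1, compound 2 and compound 3 can be read. The compounds shown leave open whether the group on the nitrogen affects inhibition at all.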